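The compounds below may be only part of what the source reports. "The series", "measured", "known", "first", "only" and "open" are said of these compounds alone.

In a functional assay on DU-145 cells (Homo sapiens) for antiproliferative activity, read by MTT assay, with a stated time of 48 h (a lower number here means a stronger inhibitor, a higher number a weaker inhibitor), compound 1 (`Cc1ccc(S(=O)(=O)NCC(=O)N2Cc3ccccc3[C@@H](OCc3ccccc3)[C@@H]2CO)cc1`) gives 3800 nM and compound 2 (`Cc1ccc(S(=O)(=O)N[C@@H](C)C(=O)N2Cc3ccccc3[C@@H](OCc3ccccc3)[C@@H]2CO)cc1`) gives 4670 nM so compound 2 stands level with compound 1 within the scatter. Compound 3 (`Cc1ccc(S(=O)(=O)N[C@H](C(=O)N2Cc3ccccc3[C@@H](OCc3ccccc3)[C@@H]2CO)C(C)C)cc1`) has isopropyl in place of methyl on a saturated chain carbon bound to a carbonyl carbon and a sulfonamide nitrogen. Going by the values given here, the only measured step at that carbon (a 1.2-fold higher number from compound 1 to compound 2 (0.09 log units; within the scatter)) stays within the scatter, so no shift beyond the scatter is expected in this assay although a single step is thin evidence. The expected step is small (a 1.1-fold higher number from compound 2 to compound 3 (0.03 log units; within the scatter)). Compound 3 is estimated at 5000 nM with an expected range from 2000 nM to 12000 nM for this measurement.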

Compound 3, half-maximal inhibitory concentration: 31600 nM
The estimate for compound 3 lay 6.3-fold (0.80 log units) below the measured number; measured number above the stated range.
By their numbers in this assay, from the lowest: compounds 1 and 2 (each within the scatter of the next); then compound 3.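

On the saturated chain carbon bound to a carbonyl carbon and a sulfonamide nitrogen, substitution in this assay is not neutral after all: isopropyl in place of methyl gives a 6.8-fold higher number from compound 2 to compound 3 (0.83 log units; beyond the scatter) and isopropyl in place of hydrogen gives an 8.3-fold higher number from compound 1 to compound 3 (0.92 log units; beyond the scatter) at this carbon. Among these compounds, methyl at this carbon stays level with hydrogen, and only isopropyl moves the number beyond the scatter. Nothing available explains this change. As far as these compounds go, whether the loss follows from branching or from carbon count alone remains open, since a straight propyl chain at this carbon would separate the two. An amine or carboxylic acid on this chain also remains untested in the compounds shown here.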